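The compounds below may be only part of what the source reports. "The series", "measured", "known", "first", "only" and "open" are said of these compounds alone.

Measured compounds in a functional assay on cells (Platelet) for inhibition; a higher number here means a weaker inhibitor, a lower number a stronger inhibitor:
- compound 1, `CCc1nn2c(=O)c(F)c(N3CCNCC3)nc2s1`: 8300 nM
- compound 2, `C[C@H](N)C(=O)Nc1cccc(-c2nn3c(=O)cc(N4CCNCC4)nc3s2)c1`: 5870 nM
- compound 3, `CCc1nn2c(=O)cc(N3CCN(C)CC3)nc2s1`: > 100000 nM

Compound 2 gives the lower of the two numbers in this assay, yet compound 1 stands close to it, and the gap between the two lies within the usual scatter, so no order between compound 1 and compound 2 can be read from these values. Compound 3 is a different case: its value is a limit of this assay and not a number, namely (the limit of > 100000 nM in this assay, at which 1 of the 3 values shown sits). Nothing further is said of compound 3 here beyond that limit.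

The step under study goes from compound 2 to compound 4, `O=C(O)c1cccc(-c2nn3c(=O)cc(N4CCNCC4)nc3s2)c1`. The change is carboxy in place of ((1-aminoethyl)carbonyl)amino on an aromatic carbon. The shared core of compound 2 and compound 4 and the six-membered aromatic ring of carbon only are kept; only the group meta to a large group on that ring is exchanged.

Going by the values given here, no step between measured compounds touches this position, so no measured change can be pointed to for its size or direction. The carboxy group brings fewer hydrogen-bond donors and acceptors than the ((1-aminoethyl)carbonyl)amino group it replaces, and the defined stereocentre is lost. In the absence of any comparable step, the expectation is a weakening of modest size, a 2.0-fold higher number from compound 2 to compound 4 (0.31 log units; beyond the scatter), with a wide margin in both directions. Compound 4 is expected to give about 12000 nM in this assay, estimated within a range from 3000 nM to 50000 nM.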

Compound 4, half-maximal inhibitory concentration: 80000 nM
Beside the measured number, compound 4's estimate is 6.7-fold (0.82 log units) below it; measured number outside the range, above it.
By their numbers in this assay, from the lowest: compounds 2 and 1 (each within the scatter of the next); then compound 4. At a limit, above all of these: compound 3.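

Going by these compounds alone, the first measured step at this position, carboxy in place of ((1-aminoethyl)carbonyl)amino on an aromatic carbon, gives in this assay a 14-fold higher number from compound 2 to compound 4 (1.13 log units; beyond the scatter) and so marks this place as one where the choice of group matters greatly to the number. The shared core, the piperazine-free description of which is not needed here, is kept throughout this pair, so the whole step belongs to this one exchange, in which the defined stereocentre leaves together with the rest of the group. No measurement shown gives a cause for the size of this step.

Within the data shown here, the single exchange does not separate what the carboxylic acid brings from what the ((1-aminoethyl)carbonyl)amino group takes with it, and the opposite stereocentre in that group stays open as well. A primary amine, a primary carboxamide or a methyl ester on the same aromatic carbon, and an acetylamino group without the amine and stereocentre, would show which part of the leaving group or of the entering carboxy carries this step.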